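The source may hold more compounds than are shown below. What is called first, only, known or untested is meant among the compounds shown, and "the series" means these compounds.

Measured so far in a functional assay on Caco-2 cells (Homo sapiens), read by MTT assay, with a stated time of 48 h; on this read-out lower numbers stand for stronger inhibition and higher numbers for weaker inhibition:

- compound 1, `CCn1c(C(=O)NCCN(C)C)ccc1C(CC)(CC)c1ccc(OCC(=O)C(C)(C)C)c(C)c1`: 1600 nM
- compound 2, `CCn1c(C(=O)NCCN(C)C)ccc1C(CC)(CC)c1ccc(OCC(O)C(C)(C)C)c(C)c1`: 1300 nM

Compound 2 gives the lowest of the two numbers in this assay; its nearest neighbour is compound 1, and the step of a 1.2-fold lower number from compound 1 to compound 2 (0.09 log units; within the scatter) lies within the scatter, so the two compounds are not told apart by this read-out.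

Compound 3, `C#CCNC(=O)c1ccc(C(CC)(CC)c2ccc(OCC(O)C(C)(C)C)c(C)c2)n1CC`, has not yet been measured. It differs from compound 2 as follows: ethynyl in place of (dimethylamino)methyl on a saturated chain carbon bound to an amide-type nitrogen. Among the compounds with values here, the change sits on the amide side chain, a place that no measured step touches. Within the data shown here, the only step on record, a 1.2-fold lower number from compound 1 to compound 2 (0.09 log units; within the scatter), concerns the saturated chain carbon bound to the oxygen on the aromatic ring and tells nothing about what the carbamoyl side chain contributes. There is therefore no measured basis for expecting a step beyond the scatter in either direction; the expectation rests only on the similarity of the shared core of compound 2 and compound 3 and carries a wide range.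

The expected step from compound 2 is a 1.4-fold higher number from compound 2 to compound 3 (0.14 log units; within the scatter). For compound 3 the estimate in this assay is 1800 nM, with a range from 600 nM to 6000 nM.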

Compound 3, half-maximal inhibitory concentration: 39100 nM
Beside the measured number, compound 3's estimate is 22-fold (1.34 log units) below it; the whole stated range lies below it.
By their numbers in this assay, from the lowest: compounds 2 and 1 (each within the scatter of the next); then compound 3.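

Working notes: in this assay, the amide side chain is a position where the read-out responds strongly, with the change from (2-(dimethylamino)ethyl)carbamoyl to propargylcarbamoyl giving a 30-fold higher number from compound 2 to compound 3 (1.48 log units; beyond the scatter), whereas the only earlier step, a 1.2-fold lower number from compound 1 to compound 2 (0.09 log units; within the scatter), on the saturated chain carbon bound to an oxygen on an aromatic ring, did not separate its two compounds. The change swaps (dimethylamino)methyl, with its nitrogen and its one hydrogen-bond acceptor, for ethynyl, which has no nitrogen and no hydrogen-bond acceptor, so this single step cannot show whether the loss of the former or the arrival of the latter accounts for the higher number. No measurement on hand bears on why the number moves this far.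

Open, from the compounds shown here alone, is whether the dimethylamino nitrogen itself is needed, which a plain propyl chain, a morpholine or a primary amine at the end of the same side chain would help to settle. Also open, going by these compounds, are the effects of a longer chain carrying the dimethylamino group and of a carboxylic acid at that chain end.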